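A few compounds are considered here, and "the series" means these few. Any claim that something is new, unique, unknown or untested is made for them only; others in the source may bear on it.

Working notes on the series. For the measured compounds named here, the shared core carries a methoxy-substituted hydroxyphenyl on one side and a thioether-linked benzyl on the other, and the three measured members differ only in the substituent on that benzyl ring. In a functional assay on cells (T-cell, Mus musculus, strain BALB/c) for inhibition, read by MTT assay, with stated times of 24 h and 72 h (on this read-out higher numbers stand for weaker inhibition and lower numbers for stronger inhibition), compound 1 `COc1cc(-c2nnc(SCc3ccc([N+](=O)[O-])cc3)o2)ccc1O` gives 14200 nM and compound 2 `COc1cc(-c2nnc(SCc3cccc([N+](=O)[O-])c3)o2)ccc1O` gives 16000 nM. Compound 3 `COc1cc(-c2nnc(SCc3ccccc3C)o2)ccc1O` gives 8420 nM in this assay; its number is the lowest of the three, but both gaps to compound 1 and to compound 2 lie within the scatter, so nothing can be read from that order.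

The next step goes from compound 3 to compound 4 `COc1cc(-c2nnc(SCc3ccccc3)o2)ccc1O`. The difference is hydrogen in place of methyl on an aromatic carbon — the 2-methylphenyl of compound 3 becomes a plain phenyl. Going by the values given here, no measured pair in the set shows the same change, so there is no step to lean on. Because compound 3 gives 8420 nM and the methyl is the only thing removed, the expected step of a 1.3-fold higher number from compound 3 to compound 4 (0.12 log units; within the scatter) is small, at most a mild weakening, likely inside the scatter. Compound 4 is therefore estimated at 11000 nM in this assay, with a range from 5000 nM to 26000 nM.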

Compound 4, half-maximal inhibitory concentration: 1250 nM
Compound 4: the middle estimate sits 8.8-fold (0.94 log units) above what was measured; measured number below the stated range.
By their numbers in this assay, from the lowest: compound 4; then compounds 3, 1 and 2 (each within the scatter of the next).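

In this assay the plain phenyl stands apart from every substituted member of the series: removing the methyl gives a 6.7-fold lower number from compound 3 to compound 4 (0.83 log units; beyond the scatter) and removing the nitro gives a 13-fold lower number from compound 2 to compound 4 (1.11 log units; beyond the scatter) and an 11-fold lower number from compound 1 to compound 4 (1.06 log units; beyond the scatter). The earlier compounds, all within the scatter of one another, could not show this; now methyl and nitro alike go with higher numbers than hydrogen on this ring, and no compound shown goes against that. No measurement here bears on why the number falls so far on removing either group.

On these data alone, it remains open whether any group on this ring can match hydrogen, for instance a fluorine, an amine or a carboxylic acid. The methoxy and hydroxyl on the other side of the core stay fixed throughout, so their part in the numbers is also untested.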